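This account rests on a few compounds, and the source may have more. Where it says the series, first, only, none or still open, it means among the compounds named here.

Measured compounds: compound 1 `CN(c1ccccc1)S(=O)(=O)c1ccc(NC(=O)c2ccc(Cl)cc2Cl)cc1`, compound 2 `Cc1cc(Cl)ccc1C(=O)Nc1ccc(S(=O)(=O)Nc2ccccc2)cc1` and compound 3 `O=C(Nc1ccc(S(=O)(=O)Nc2ccc(Cl)cc2)cc1)c1ccc(Cl)cc1Cl`. In a functional assay on HEK293 cells for agonist activity at probable G-protein coupled receptor 27 (Homo sapiens), read by a luciferase reporter and beta-arrestin recruitment, with a stated time of 10 min (a higher number here means that more compound is needed for the effect, a lower number that less compound is needed), compound 1 gives 2570 nM. In this assay compound 2 gives 912 nM. For compound 3 this assay reports only a limit, > 100000 nM.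

Compound 3 thus sits at the limit of > 100000 nM in this assay, at which 1 of the 3 values shown sits, with no number of its own. Compound 4 `O=C(Nc1ccc(S(=O)(=O)Nc2ccccc2)cc1)c1ccc(Cl)cc1Cl` differs from it by hydrogen in place of chloro on an aromatic carbon. Among the measured compounds shown here, only one measured step touches this region, an at least 38-fold higher number from compound 1 to compound 3 (1.59 log units; beyond the scatter), but it changes the group on the sulfonyl nitrogen together with the chloro and so does not isolate the chloro alone. Compound 2, which also carries an anilino group, gives 912 nM. Compound 4 is therefore expected to move back toward measurable activity, an at least 40-fold lower number from compound 3 to compound 4 (1.60 log units; beyond the scatter). Compound 4 is estimated at 2500 nM, between 500 nM and 40000 nM.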

Compound 4, half-maximal effective concentration: 457 nM
Compound 4: the middle estimate sits 5.5-fold (0.74 log units) above what was measured, outside the stated range (below it).
By their numbers in this assay, from the lowest: compounds 4 and 2 (each within the scatter of the next); then compound 1. At a limit, above all of these: compound 3.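

In this assay, the chloro para to a large group is now isolated as a single change, and removing it gives an at least 210-fold lower number from compound 3 to compound 4 (2.34 log units; beyond the scatter), a step read against a limit. Hydrogen in place of methyl on the sulfonamide nitrogen gives only a 5.6-fold lower number from compound 1 to compound 4 (0.75 log units; beyond the scatter), so the large loss in compound 3 goes with the chloro, not with that nitrogen hydrogen. Chloro in place of methyl on the other aromatic carbon gives a 2.0-fold lower number from compound 2 to compound 4 (0.30 log units; within the scatter).

On these data alone, it remains open whether a fluoro, methyl or methoxy at the para carbon would cost as much as chloro. Also open, as far as these compounds go, is how an amine or a carboxylic acid there would behave.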